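A few compounds are considered here, and "the series" means these few. Any claim that something is new, unique, unknown or untested is made for them only; others in the source may bear on it.

Measured in a functional assay on KB cells (Homo sapiens) for cytotoxicity; a higher number here means a weaker inhibitor, a lower number a stronger inhibitor:
compound 1 `Cc1ccc(S(=O)(=O)Oc2cccc3c2C(=O)C=CC3=O)cc1` gives 10700 nM
compound 2 `COc1ccc2c(c1)C(=O)C=CC2=O` gives 33900 nM
compound 3 `CC(=O)OC1=CC(=O)c2ccccc2C1=O` gives 38800 nM

Compound 2 stands level with compound 3 within the usual scatter of this kind of measurement. Compound 1 shows a clearly lower number than compound 2, which means stronger inhibition.

The next compound to be tested is compound 4 `O=C1C=CC(=O)c2cc(Oc3cccs3)ccc21`. Relative to compound 2 the change is thiophen-2-yl in place of methyl on an oxygen on an aromatic ring in short, thiophen-2-yl in place of methyl on an oxygen on an aromatic ring, so methoxy becomes (thiophen-2-yl)oxy.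

Among the compounds with values here, no two measured compounds differ in only one place, so nothing here shows this change directly. Within the data shown here, the only hint is compound 1 at 10700 nM with its own large group on an oxygen, although it differs from compound 2 in other ways too. A modest gain in strength is therefore expected, perhaps only just beyond the scatter. The expected change is a 2.1-fold lower number from compound 2 to compound 4 (0.33 log units; beyond the scatter) and points toward a lower number. For compound 4 the estimated value is 16000 nM (expected range 5000 nM to 45000 nM).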

Compound 4, half-maximal inhibitory concentration: 18300 nM
The estimate for compound 4 lay 1.1-fold (0.06 log units) below the measured number; the measured number falls inside the stated range.
By their numbers in this assay, from the lowest: compounds 1, 4, 2 and 3 (each within the scatter of the next, the first and the last beyond it).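

In this assay, within the data shown here, thiophen-2-yl in place of methyl on an oxygen on an aromatic ring gives a 1.9-fold lower number from compound 2 to compound 4 (0.27 log units; within the scatter), the first direct reading of a change at this place. This oxygen can therefore carry a five-membered aromatic ring of 5 heavy atoms instead of a single methyl carbon with no difference that stands clear of the scatter. No measurement on hand accounts for this result.

On these data alone, it remains open whether any other group on this oxygen would move the number beyond the scatter, such as a phenyl ring, a longer chain or a chain ending in an amine. Compound 1 differs from compound 4 in more than one place, so it cannot settle this question.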